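The source may hold more compounds than are shown below. What is called first, only, known or untested is meant among the compounds shown, and "the series" means these compounds.

Three compounds share one core. Compound 1 is `Cc1ccc(S(=O)(=O)NC2=NCCN2C(=S)SN2CCn3c2nsc3=S)cc1`, compound 2 is `O=S(=O)(NC1=NCCN1C(=S)SN1CCn2c1nsc2=S)c1ccc(C(F)(F)F)cc1` and compound 3 is `O=S(=O)(NC1=NCCN1C(=S)SN1CCn2c1nsc2=S)c1cccc(Cl)c1`. In a functional assay on KYSE-510 cells (Homo sapiens) for antiproliferative activity, read by crystal violet staining, with a stated time of 96 h (a lower number here means a stronger inhibitor of growth, a higher number a weaker inhibitor of growth), compound 1 gives >= 20000 nM, which is a limit of the assay and not a number. Compound 2 likewise gives only a limit in this assay, namely >= 20000 nM. Compound 3 also sits at a limit in this assay, namely >= 20000 nM. Compound 2 thus stands at the same limit as the other two measured compounds, with no number of its own. The steps between the measured compounds carry no readable size: a step that the two limits leave unreadable from compound 1 to compound 2, a step that the two limits leave unreadable from compound 1 to compound 3 and a step that the two limits leave unreadable from compound 2 to compound 3, because of the limit of >= 20000 nM in this assay, at which 3 of the 3 values shown sit. Compound 4 is `O=S(=O)(NC1=NCCN1C(=S)SN1CCn2c1nsc2=S)c1ccc(Cl)cc1` and has not yet been measured. Against compound 2 the change is chloro in place of trifluoromethyl on an aromatic carbon. Among the compounds with values here, no measured step gives a readable size that bears on this change. Every change at the aromatic ring seen so far left the value at the limit, so compound 4 is expected to remain there too, with the estimated step of a number no higher from compound 2 to compound 4 (the limit leaves the size open). Compound 4 is estimated at 20000 nM, within a range from 6000 nM to 60000 nM.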

Compound 4, concentration for 50% growth inhibition: >= 20000 nM
Compound 4 gave a limit, no number; the forecaster's own chance of this, stated with the estimate: 80%; the middle value lies on the limit itself.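

Compound 4 also sits at a limit in this assay, not a number, so its steps from compound 1, compound 2 and compound 3 cannot be read: the limit of >= 20000 nM in this assay, at which 4 of the 4 values shown sit. The compounds shown leave open whether any change to the aromatic ring or the shared core gives a readable value.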